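Removal of the acetyl group in the allyl series

The source may hold more compounds than are shown below. What is called first, only, known or untested is meant among the compounds shown, and "the series" means these compounds.

Compound 1 `CC(=O)c1ccc(OCCCCC#N)cc1O` gives 0% in an assay on isolated protein for inhibition of leukotriene B4 receptor 1 (Homo sapiens), tested at 10 uM; on this read-out lower numbers stand for less inhibition and higher numbers for more inhibition at the one concentration tested (going by the name of the read-out). Compound 2 `CC(=O)c1cc(C(C)=O)c(OCCCCC#N)cc1O` gives 8% in this assay, and compound 3 `C=CCc1cc(C(C)=O)c(O)cc1OCCCCC#N` gives 92%, the highest of the three numbers. The change from compound 2 to compound 1, (hydrogen in place of acetyl on an aromatic carbon), gave a number 8 percentage points lower from compound 2 to compound 1 (within the scatter). Compound 2 and compound 3 differ by allyl in place of acetyl on an aromatic carbon, which gave a number 84 percentage points higher from compound 2 to compound 3 (beyond the scatter); the step of a number 92 percentage points higher from compound 1 to compound 3 (beyond the scatter) is of the same order.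

Compound 4 `C=CCc1ccc(O)cc1OCCCCC#N` has not yet been measured. It differs from compound 3 by hydrogen in place of acetyl on an aromatic carbon, the same kind of change as that from compound 2 to compound 1, but not the same: in compound 3 the carbon that loses the acetyl is ortho to a hydroxy group, meta to an allyl group and para to a group of 7 heavy atoms, whereas in compound 2 it is ortho to a group of 7 heavy atoms, meta to an acetyl group and para to a hydroxy group.

Among the measured compounds shown here, the one precedent for the change is compound 2 to compound 1, where a number 8 percentage points lower from compound 2 to compound 1 (within the scatter) stayed within the scatter, so a step of similar size, a number 22 percentage points lower from compound 3 to compound 4 (beyond the scatter), is expected here, with wide uncertainty since the surroundings of the place differ. Compound 4 is estimated at 70%, between 30% and 95%.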

Compound 4, a percentage reported as inhibition, at one concentration (the size of the read-out at that concentration, not a potency): 29%
The estimate for compound 4 lay 41 percentage points above the measured number, and the stated range ends above it.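

In this assay, hydrogen in place of acetyl on an aromatic carbon gave a number 63 percentage points lower from compound 3 to compound 4 (beyond the scatter), so this change does not carry over as a fixed step from the core of compound 2 to the core of compound 3: the same change on two cores in this assay, a number 8 percentage points lower (within the scatter) from compound 2 to compound 1 and a number 63 percentage points lower (beyond the scatter) from compound 3 to compound 4, 55 percentage points apart, beyond the scatter of two such steps The two pairs show that the size of the step depends on the core, but compound 2 starts at 8%, which leaves its step little room to fall, so the smaller step may say little about the acetyl itself. Two pairs give no rule for a third core and do not show which difference between the cores sets the gap.

Open, going by these compounds, is whether a group other than hydrogen, such as an amide or a carboxylic acid, could stand in place of the acetyl on the core of compound 3 and keep the number high, and whether a longer chain or a carboxylic acid in place of the nitrile would do the same. Percentages at one concentration also leave the potency of compound 3 and compound 4 open.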